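This account rests on a few compounds, and the source may have more. Where it says the series, first, only, none or still open, it means among the compounds named here.

The shared core of compound 1 `C=CCCCCOc1ccccc1-c1cnc(OCCC=C)n1C` and compound 2 `C=CCCCCOc1ccc(OC)cc1-c1cnc(OCCC=C)n1C` carries a pendant aromatic ring with a (hex-5-en-1-yl)oxy group, while compound 3 `C=CCCCCOc1ncc(-c2ccccc2OC)n1C` places the chain on the other ring and leaves a methoxy on the pendant ring. The difference between the core of compound 1 and the core of compound 3 is not broken down here.

In a functional assay on PC-3 cells (Homo sapiens) for inhibition, read by colorimetric assay and MTT assay, with a stated time of 72 h (a lower number here means a stronger inhibitor, a higher number a weaker inhibitor), compound 1 gives 19000 nM. In this assay compound 2 gives 43000 nM, and the step of a 2.3-fold higher number from compound 1 to compound 2 (0.35 log units; beyond the scatter) rests on (methoxy in place of hydrogen on an aromatic carbon). In this assay compound 3 gives 24000 nM, a number that sits within the scatter of compound 1 and of compound 2, so no order among the three can be read from it.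

Compound 4 `C=CCCCCOc1ncc(-c2cccc(OC)c2OC)n1C` is not yet measured. It differs from compound 3 by methoxy in place of hydrogen on an aromatic carbon. Going by the values given here, this is the same kind of change as the one from compound 1 to compound 2, but the surroundings differ: in compound 2 the new methoxy is meta to a large group and para to a (hex-5-en-1-yl)oxy group, whereas in compound 4 it is ortho to a methoxy group and meta to a large group. Because a 2.3-fold higher number from compound 1 to compound 2 (0.35 log units; beyond the scatter) was modest, a step of similar size is expected for compound 4, namely a 1.9-fold higher number from compound 3 to compound 4 (0.27 log units; within the scatter). In this assay compound 4 is therefore estimated at 45000 nM, between 18000 nM and 110000 nM.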

Compound 4, half-maximal inhibitory concentration: 36000 nM
The estimate for compound 4 lay 1.3-fold (0.10 log units) above the measured number, and the stated range covers the measured number.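

In this assay, methoxy in place of hydrogen on an aromatic carbon gives a 1.5-fold higher number from compound 3 to compound 4 (0.18 log units; within the scatter), so on the core of compound 3 this step cannot be told apart from no change at all. Set beside the earlier step, the result gives no sign that the change behaves differently on the two cores: the same change on two cores in this assay, a 2.3-fold higher number (0.35 log units; beyond the scatter) from compound 1 to compound 2 and a 1.5-fold higher number (0.18 log units; within the scatter) from compound 3 to compound 4, 1.5-fold (0.18 log units) apart, within the scatter of two such steps. Going by these compounds alone, this shows only that the two steps agree within the scatter, and it does not establish a rule for carrying the change across the series, since there are just two cores, only the step on the core of compound 1 lies beyond the scatter, and the new methoxy in compound 4 stands in different surroundings, ortho to a methoxy group and meta to a large group, so that core and surroundings cannot be separated.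

The compounds shown leave open whether another group in place of that hydrogen, such as a fluorine, an amine or a carboxylic acid, would give a step beyond the scatter on either core. They also leave open whether a longer chain in place of the alkenyl ether chains would alter how the methoxy step carries over.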